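Mirror-image side chain on a shared core

The source may hold more compounds than are shown below. What is called first, only, known or untested is meant among the compounds shown, and "the series" means these compounds.

Compound 1 `CCCN(CC(=O)N(C)C)c1nc(C)nc2c1c(C)nn2-c1ccc(OC)cc1C` gives 1410 nM in a functional assay on CHO cells for antagonist activity at corticotropin-releasing factor receptor 1 (Homo sapiens), read by cAMP accumulation; a higher number here means a weaker inhibitor, a lower number a stronger inhibitor.
Compound 2 `CCCNCc1nnc(Nc2nc(C)nc3c2c(C)nn3-c2ccc(OC)cc2C)o1` gives 996 nM in this assay.
Compound 3 `CC[C@@H](COC)Nc1nc(C)nc2c1c(C)nn2-c1ccc(OC)cc1C` gives 135 nM in this assay.

Compound 3 has the lowest number of the three, with a 7.4-fold lower number from compound 2 to compound 3 (0.87 log units; beyond the scatter) and a 10-fold lower number from compound 1 to compound 3 (1.02 log units; beyond the scatter) both beyond the scatter. Compound 4 `CC[C@H](COC)Nc1nc(C)nc2c1c(C)nn2-c1ccc(OC)cc1C` is its mirror image at one point: the two compounds have the same atoms and bonds and differ only in configuration as drawn: 1 of 1 stereo elements differ; a stereocentre at a saturated chain carbon is drawn S in compound 3 and R in compound 4. Neither measured step bears on this change, since both swapped whole groups rather than configuration, so no shown step gives a direction or size. Such a swap commonly leaves the number unchanged or makes it higher; a large lowering is less usual. For compound 4 the expected step is a 3.0-fold higher number from compound 3 to compound 4 (0.47 log units; beyond the scatter), a somewhat higher number in this assay. Compound 4 is therefore estimated at 400 nM, with a range from 100 nM to 1600 nM.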

Compound 4, inhibition constant: 210 nM
Compound 4: middle estimate off by 1.9-fold (0.28 log units), on the high side; the range from low to high includes it.
By their numbers in this assay, from the lowest: compounds 3 and 4 (each within the scatter of the next); then compounds 2 and 1 (each within the scatter of the next).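

In this assay, inverting the stereocentre at this saturated chain carbon gives a 1.6-fold higher number from compound 3 to compound 4 (0.19 log units; within the scatter), so neither drawn configuration is clearly preferred. The 1-(methoxymethyl)propyl group keeps its lead in the R form too, with a 4.7-fold lower number from compound 2 to compound 4 (0.68 log units; beyond the scatter) and a 6.7-fold lower number from compound 1 to compound 4 (0.83 log units; beyond the scatter), so that lead does not depend on the S form alone. The comparison between the two forms is a clean one: the fact that compounds 3 and 4 differ only in the configuration as drawn.

Going by these compounds, it remains open whether a hydroxyl group or a longer alkyl chain in place of the methoxymethyl group would change the number, and whether configuration would then matter more.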